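The source may report more compounds than this note shows. Statements on the series, on what has been measured and on what is new or still open speak of the compounds shown alone.

Measured in a functional assay on NCI-H23 cells (Homo sapiens) for cytotoxicity, read by colorimetric assay; on this read-out lower numbers stand for stronger inhibition and higher numbers for weaker inhibition:
- compound 1 `O=C(/C=C/c1ccc(CN2C(=O)/C(=C3\Nc4ccccc4\C3=N/O)c3cccc(Cl)c32)cc1)NO`: 50 nM
- compound 2 `O=C(NO)c1ccc(CN2C(=O)/C(=C3\Nc4ccccc4\C3=N/O)c3cc(Cl)ccc32)cc1`: 50 nM
- compound 3 `O=C(NO)c1ccc(CN2C(=O)/C(=C3\Nc4ccccc4\C3=N/O)c3cc(F)ccc32)cc1`: 30 nM

In this assay, compound 1 stands level with compound 2, and compound 3 lies within the usual scatter of both. These three numbers therefore cannot be ranked.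

The next compound is compound 4 `O=C(NO)c1ccc(CN2C(=O)/C(=C3\Nc4ccccc4\C3=N/O)c3cccc(Cl)c32)cc1`. It has hydroxycarbamoyl in place of 2-(hydroxycarbamoyl)ethenyl on an aromatic carbon of compound 1: hydroxycarbamoyl in place of 2-(hydroxycarbamoyl)ethenyl on an aromatic carbon.

Within the data shown here, no measured step covers this exchange directly. Among the measured compounds shown here, the only single-place step, a 1.7-fold lower number from compound 2 to compound 3 (0.22 log units; within the scatter), is a different change, fluoro in place of chloro on an aromatic carbon, so it bears on compound 4 only indirectly. It does show how little the numbers have moved so far. With nothing else to go on, no step beyond the scatter is expected in this assay.

The estimated step is a 1.3-fold lower number from compound 1 to compound 4 (0.10 log units; within the scatter), which would stay within the scatter.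

For compound 4 the expected value is 40 nM, with an estimated range from 15 nM to 110 nM.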

Compound 4, half-maximal inhibitory concentration: 60 nM
The estimate for compound 4 lay 1.5-fold (0.18 log units) below the measured number; measured number inside the range.
By their numbers in this assay, from the lowest: compounds 3, 1, 2 and 4 (each within the scatter of the next).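

In this assay, among these compounds, the exchange of 2-(hydroxycarbamoyl)ethenyl for hydroxycarbamoyl gives a 1.2-fold higher number from compound 1 to compound 4 (0.08 log units; within the scatter) and so offers the first look at this place on the ring of carbon only, para to a large group. Among the compounds shown here, the only earlier step swapped one halogen for another at a different place, whereas this one shortens the group from 6 heavy atoms to 4 and removes one double bond, yet the number stays within the scatter. For this one pair the shorter group therefore serves as well as the longer one on this read-out, although nothing measured here explains that result.

From the compounds shown here alone, it remains open whether the number would hold with a carboxylic acid or a primary amide at this place. A longer saturated chain ending in hydroxycarbamoyl is equally untested by the compounds shown.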